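The source may report more compounds than this note shows. Statements on the series, on what has been measured and on what is new or still open speak of the compounds shown alone.

Measured compounds:
- compound 1 `CN1CCC(n2cc(S(=O)(=O)c3ccccc3F)c3cccnc32)C1`: 186 nM
- compound 2 `CN1CCC(n2cc(S(=O)(=O)c3ccccc3Cl)c3cccnc32)C1`: 91 nM

For the measured compounds named here, in a functional assay on HeLa cells for antagonist activity at 5-hydroxytryptamine receptor 6 (Homo sapiens), read by cAMP accumulation and immunoassay (a higher number here means a weaker inhibitor, a lower number a stronger inhibitor), compound 2 gives 91 nM, the lowest of the two numbers; the nearest is compound 1 at 186 nM, the single measured step being a 2.0-fold lower number from compound 1 to compound 2 (0.31 log units; beyond the scatter). Compound 3 `CN1CCC(n2cc(S(=O)(=O)c3cccc(Cl)c3)c3cccnc32)C1` differs from compound 2 by 3-chlorophenyl in place of 2-chlorophenyl on a sulfonyl sulfur. Going by the values given here, the one measured step exchanges halogens and does not bear on relocating the chloro; no measured step covers this change. No step beyond the scatter is therefore expected in this assay. The estimate for compound 3 is 110 nM (range 35 nM to 350 nM), that is a 1.2-fold higher number from compound 2 to compound 3 (0.08 log units; within the scatter).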

Compound 3, half-maximal inhibitory concentration: 142 nM
Beside the measured number, compound 3's estimate is 1.3-fold (0.11 log units) below it; measured number inside the range.
By their numbers in this assay, from the lowest: compounds 2, 3 and 1 (each within the scatter of the next, the first and the last beyond it).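

Moving the chlorine on the phenyl attached to the sulfonyl sulfur gives a 1.6-fold higher number from compound 2 to compound 3 (0.19 log units; within the scatter) in this assay and so shows no separable preference between 2-chlorophenyl and 3-chlorophenyl. Replacing 2-fluorophenyl gives a 1.3-fold lower number from compound 1 to compound 3 (0.12 log units; within the scatter) here, so of these two chlorophenyl groups only 2-chlorophenyl is separated from 2-fluorophenyl beyond the scatter. Nothing available accounts for either step.

Still open, on these data alone, is how a methoxy group or an amine would compare with chloro on this phenyl ring.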